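The source may hold more compounds than are shown below. What is called first, only, known or untested is meant among the compounds shown, and "the series" means these compounds.

Working notes on the series. Compound 1 `CN1[C@@H]2c3[nH]c4ccccc4c3C[C@H]1[C@H](C#N)N1[C@@H](CN3C(=O)c4ccccc4C3=O)c3[nH]c4ccccc4c3C[C@@H]21` and compound 2 `CN1[C@@H]2c3[nH]c4ccccc4c3C[C@H]1[C@H](C#N)N1[C@@H](CNC(=O)c3ccc4ccccc4c3)c3[nH]c4ccccc4c3C[C@@H]21` share a core and differ in the group carried on the side-chain nitrogen. In a functional assay on BGC-823 cells (Homo sapiens) for cytotoxicity, read by MTT assay, with a stated time of 72 h (on this read-out higher numbers stand for weaker inhibition and lower numbers for stronger inhibition), compound 1 gives 410 nM, and in this assay compound 2 gives 1110 nM; compound 2 thus stands with the higher of the two numbers, the gap to compound 1 lying beyond the scatter of repeat measurements. Compound 3 `COc1ccc(/C=C/C(=O)NC[C@H]2c3[nH]c4ccccc4c3C[C@H]3[C@H]4c5[nH]c6ccccc6c5C[C@@H]([C@H](C#N)N23)N4C)cc1` keeps the amide of compound 2 and alters only the acyl part: 2-(4-methoxyphenyl)ethenyl in place of naphthalen-2-yl on a carbonyl carbon. Among the measured compounds shown here, no measured pair covers a swap of this kind, so the direction is open; the single measured pair shows only that the side-chain group moves the read-out. The expected step from compound 2 to compound 3 is a 1.1-fold lower number from compound 2 to compound 3 (0.05 log units; within the scatter), not beyond the scatter. Compound 3 is therefore estimated at 1000 nM, with a range of 400 nM to 2800 nM.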

Compound 3, half-maximal inhibitory concentration: 5450 nM
Estimate against measurement, compound 3: 5.5-fold (0.74 log units) below; the measured number lies above the stated range.
By their numbers in this assay, from the lowest: compound 1; then compound 2; then compound 3.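

On the carbonyl carbon of the side-chain amide, the acyl group clearly matters: in this assay, 2-(4-methoxyphenyl)ethenyl in place of naphthalen-2-yl gives a 4.9-fold higher number from compound 2 to compound 3 (0.69 log units; beyond the scatter) with no change in the group's count of heavy atoms. A step beyond the scatter therefore arises here without any change in that count, so the count alone does not set the read-out at this place. The swap changes several things at once, replacing two six-membered aromatic rings with one, and adding a double bond outside the rings and a hydrogen-bond acceptor, and no measurement on hand bears on the reason for the step.

The compounds shown do not separate these changes, so it remains open whether the double bond, the methoxy group or the loss of the second ring carries the step. A 2-phenylethenyl group without the methoxy and a saturated 2-(4-methoxyphenyl)ethyl chain would divide them, while an acyl group carrying an amine or a carboxylic acid remains unexplored in the compounds shown.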